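This account rests on a few compounds, and the source may have more. Where it says the series, first, only, none or still open, it means among the compounds named here.

Measured compounds:
compound 1, `O=C(/C=C/c1cccc(Br)n1)c1ccc(Nc2cc(-c3ccccc3)nc3nc(SCc4ccccc4)nn23)cc1`: 38.3%
compound 2, `Cc1cc(Nc2ccc(C(=O)/C=C/c3cccc(Br)n3)cc2)n2nc(SCc3ccc([N+](=O)[O-])cc3)nc2n1`: 91.6%

In a functional assay on MGC-803 cells (Homo sapiens) for inhibition, read by sulforhodamine B assay, with a stated time of 72 h, tested at 10 uM (on this read-out higher numbers stand for more inhibition at the one concentration tested (going by the name of the read-out) and lower numbers for less inhibition), compound 2 gives 91.6%, the higher of the two numbers shown; compound 1 gives 38.3%, a gap beyond the scatter. Compound 3, `C#CCSc1nc2nc(C)cc(Nc3ccc(C(=O)/C=C/c4cccc(Br)n4)cc3)n2n1`, differs from compound 2 in one place: ethynyl in place of 4-nitrophenyl on a saturated chain carbon bound to a sulfur. Among the compounds with values here, no step between measured compounds isolates this change, so its size is unknown. The expectation for compound 3 is a decrease beyond the scatter, a number 26.6 percentage points lower from compound 2 to compound 3 (beyond the scatter), since compound 2 sits near the top of the read-out. Compound 3 is estimated at 65%, in a range from 35% to 90%.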

Compound 3, a percentage reported as inhibition, at one concentration (the size of the read-out at that concentration, not a potency): 94.4%
For compound 3 the middle estimate is 29.4 percentage points below the measured one; the whole stated range lies below it.
By their numbers in this assay, from the lowest: compound 1; then compounds 2 and 3 (each within the scatter of the next).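

In this assay the step at this place, a number 2.8 percentage points higher from compound 2 to compound 3 (within the scatter), shows that ethynyl can stand in place of 4-nitrophenyl on a saturated chain carbon bound to a sulfur without a loss of inhibition at the one concentration tested. With this pair, neither the six-membered aromatic ring nor the nitro group of 4-nitrophenyl is required to keep the read-out this high. Nothing available accounts for this result.

Both numbers lie near the top of the read-out, so a difference in potency between compound 2 and compound 3 could remain hidden. On these data alone, whether an amine, a carboxylic acid or a longer chain at this place would keep the inhibition remains open.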